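Turning the Stereocentre of Compound 2 Around

This account rests on a few compounds, and the source may have more. Where it says the series, first, only, none or still open, it means among the compounds named here.

Three compounds have been measured in an assay on membranes from Sf9 cells for displacement of a labelled ligand from histamine H2 receptor (Homo sapiens), read by scintillation counting, with a stated time of 60 min; a lower number here means a stronger inhibitor, a higher number a weaker inhibitor:

Compound 1 `N/C(=N\C(=O)NCc1ccccc1)NC1CCc2nc(N)sc2C1`: 513 nM
Compound 2 `Cc1nc(N)sc1CCCN/C(N)=N/C(=S)N[C@@H](C)c1ccccc1`: 339 nM
Compound 3 `Cc1nc(N)sc1CCCN/C(N)=N/C(=O)NC(c1ccccc1)c1ccccc1`: 43.7 nM

Compound 2 gives the second highest of the three numbers. Compound 1 lies nearest to it, within the usual scatter, so no order between compound 1 and compound 2 can be claimed. Compound 3 stands furthest away, with a lower number that lies beyond the scatter.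

Compound 4 `Cc1nc(N)sc1CCCN/C(N)=N/C(=S)N[C@H](C)c1ccccc1` differs from compound 2 as follows: the two compounds have the same atoms and bonds and differ only in configuration as drawn: 1 of 2 stereo elements differ; a stereocentre at a saturated chain carbon is drawn S in compound 2 and R in compound 4. Among the measured compounds no pair differs in this way, so the size and direction of such a step in this assay are unknown. A mirror-image partner may bind alike or differently, and the expected step from compound 2 to compound 4 is therefore small with a wide margin, a 1.2-fold higher number from compound 2 to compound 4 (0.07 log units; within the scatter). Compound 4 is thus estimated at 400 nM, within a range from 100 nM to 1600 nM.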

Compound 4, inhibition constant: 115 nM
Beside the measured number, compound 4's estimate is 3.5-fold (0.54 log units) above it; measured number inside the range.
By their numbers in this assay, from the lowest: compound 3; then compound 4; then compounds 2 and 1 (each within the scatter of the next).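

In this assay, within the data shown here, turning the stereocentre at the saturated chain carbon from S to R gives a 2.9-fold lower number from compound 2 to compound 4 (0.47 log units; beyond the scatter), which shows that the configuration at this position matters, something no earlier pair could reveal. The step can be assigned to this stereocentre alone, because nothing else separates the two structures: the fact that compounds 2 and 4 differ only in the configuration as drawn. Of this mirror-related pair, the R form gives the lower number.

The compounds shown leave open whether the same preference holds when an ethyl or a hydroxymethyl group replaces the methyl on this carbon.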